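Trifluoromethyl for ethyl on the sulfonamide aryl ring

A few compounds are considered here, and "the series" means these few. Any claim that something is new, unique, unknown or untested is made for them only; others in the source may bear on it.

Measured so far in an assay on isolated protein for inhibition of Nicotinamide phosphoribosyltransferase (Homo sapiens), read by WST assay, with stated times of 60 min, 5 min and 30 min, in the presence of a further agent that is not named here; a lower number here means a stronger inhibitor, a higher number a weaker inhibitor:
compound 1, `O=C(/C=C/c1cccnc1)NCCCCCc1ccc(S(=O)(=O)Nc2ccccc2)cc1`, 28.4 nM;
compound 2, `Cc1ccccc1NS(=O)(=O)c1cccc(CCCCCCNC(=O)/C=C/c2cccnc2)c1`, 5.08 nM;
compound 3, `CCc1ccc(NS(=O)(=O)c2cccc(CCCCCCNC(=O)/C=C/c3cccnc3)c2)cc1`, 31.5 nM.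

Compound 3 and compound 1 give numbers that lie within the scatter of each other, so neither can be called the weaker of the two. Compound 2 stands apart: a 6.2-fold higher number from compound 2 to compound 3 (0.79 log units; beyond the scatter), which shows that the group on the sulfonamide nitrogen matters for this assay.

Compound 4, `O=C(/C=C/c1cccnc1)NCCCCCCc1cccc(S(=O)(=O)Nc2ccc(C(F)(F)F)cc2)c1`, keeps the core of compound 3 and changes one thing: trifluoromethyl in place of ethyl on an aromatic carbon. Within the data shown here, no measured step covers this particular swap. Among the measured compounds shown here, the one step that touches the same ring changes both the group and where it sits, so it only says that such changes can move the number, not in which direction a trifluoromethyl would move it. The expectation for compound 4 in this assay is therefore a step of a 1.1-fold lower number from compound 3 to compound 4 (0.02 log units; within the scatter), with no direction that the data support beyond the scatter. Compound 4 is estimated at 30 nM, with a range from 10 nM to 90 nM.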

Compound 4, half-maximal inhibitory concentration: 24.5 nM
For compound 4 the middle estimate is 1.2-fold (0.09 log units) above the measured one; the range from low to high includes it.
By their numbers in this assay, from the lowest: compound 2; then compounds 4, 1 and 3 (each within the scatter of the next).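

In this assay, trifluoromethyl in place of ethyl on this ring gives a 1.3-fold lower number from compound 3 to compound 4 (0.11 log units; within the scatter), so compound 3 and compound 4 cannot be told apart at this place, para to a large group. Compound 2 remains separate from this pair: alongside the earlier step to compound 3, there is a 4.8-fold higher number from compound 2 to compound 4 (0.68 log units; beyond the scatter), showing that two different 4-substituted phenyl groups on the sulfonamide nitrogen both give numbers beyond the scatter from 2-methylphenyl. Nothing available here accounts for either result.

The compounds shown never keep one group and change only where it sits on this ring, so the effects of group and place remain tangled in the steps from compound 2. As far as these compounds go, how an amine or a carboxylic acid at this place would read also remains open.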